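Cytotoxicity notes: compound 2 without its acetyl

The compounds below may be only part of what the source reports. "The series", "measured", "known", "first", "only" and "open" are said of these compounds alone.

In an ADME assay on J774 cells (Mus musculus) for cytotoxicity (a higher number here means that more compound is needed for the effect, a lower number that less compound is needed), compound 2 `CCCCc1cc2c(=O)c(C(C)=O)c[nH]c2cc1OCCOc1ccccc1` gives "not determined" (no result reported), so it offers no single number as a starting point. Compound 1 `COC(=O)c1c[nH]c2cc(OCCOc3ccccc3)ccc2c1=O` reads > 20000 nM, which is a limit of the assay and not a number. Compound 3 `COC(=O)c1c[nH]c2ccc(Oc3ccccc3)cc2c1=O` reads > 20000 nM, which is also a limit. Compound 4 `CCCCc1cc2c(=O)cc[nH]c2cc1OCCOc1ccccc1` has not yet been measured.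

The structural change is hydrogen in place of acetyl on an aromatic carbon, two atoms from the ring nitrogen. For the measured compounds named here, no measured pair shows this change, and the missing result for compound 2 leaves no value from which to read its size. The working expectation in this assay is therefore no step beyond the usual scatter, in either direction. The only reference point for that expectation is the limit of > 20000 nM in this assay, at which 2 of the 3 values shown sit, and a limit is again the likely outcome. For compound 4 the estimated value is 20000 nM, with an expected range from 7000 nM to 40000 nM.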

Compound 4, half-maximal effective concentration: > 20000 nM
Compound 4: a limit, no number (the forecaster's own chance of this, stated with the estimate: 70%); the middle value lies on the limit itself.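

No step can be read from these results: compound 2 is reported as not determined, and compound 4 sits at a limit of the assay, not a number: the limit of > 20000 nM in this assay, at which 3 of the 4 values shown sit.

What hydrogen in place of acetyl does in this assay stays open, since the compounds shown give no single number to compare.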